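The source may hold more compounds than are shown below. What is called first, only, known or untested is meant among the compounds shown, and "the series" means these compounds.

Compound 1 `COc1cc(/C=C/C(=O)c2cccc(-n3cc(-c4ccc(Cl)cc4)[nH]c3=O)c2)cc(OC)c1OC` gives 5070 nM in a functional assay on SF-268 cells (Homo sapiens) for inhibition; on this read-out lower numbers stand for stronger inhibition of growth and higher numbers for weaker inhibition of growth. Compound 2 `O=C(/C=C/c1cccc(O)c1)c1cccc(-n2cc(-c3ccccc3)[nH]c2=O)c1` gives 4530 nM. Compound 3 `O=C(/C=C/c1cccc(O)c1)c1cccc(-n2cc(-c3ccc(Cl)cc3)[nH]c2=O)c1` gives 1780 nM.

Of the three, compound 1 carries the highest number; its gap to compound 2 lies within the scatter, while its gap to compound 3 lies beyond it. Compound 4 `COc1cc(/C=C/C(=O)c2cccc(-n3cc(-c4ccccc4)[nH]c3=O)c2)cc(OC)c1OC` differs from compound 1 by hydrogen in place of chloro on an aromatic carbon. For the measured compounds named here, only one measured step bears on this change, and it runs the other way: a 2.5-fold lower number from compound 2 to compound 3 (0.41 log units; beyond the scatter), in which chloro entered. Read backwards, that step makes a modest rise in the number expected from compound 1 to compound 4, namely a 2.5-fold higher number from compound 1 to compound 4 (0.39 log units; beyond the scatter). Compound 4 is therefore estimated at 12500 nM, with a range from 5000 nM to 32000 nM.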

Compound 4, concentration for 50% growth inhibition: 1920 nM
Estimate against measurement, compound 4: 6.5-fold (0.81 log units) above; the measured number lies below the stated range.
By their numbers in this assay, from the lowest: compounds 3 and 4 (each within the scatter of the next); then compounds 2 and 1 (each within the scatter of the next).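

Going from 4-chlorophenyl to phenyl gives a 2.6-fold lower number from compound 1 to compound 4 (0.42 log units; beyond the scatter) in this assay, so chloro at this place does not lower the number on every core. The outcome of this change depends on the rest of the molecule, and its direction reverses between the two pairs: the same change on two cores in this assay, a 2.5-fold lower number (0.41 log units; beyond the scatter) from compound 2 to compound 3 and a 2.6-fold higher number (0.42 log units; beyond the scatter) from compound 4 to compound 1, 6.7-fold (0.83 log units) apart, beyond the scatter of two such steps

The compounds shown leave open whether fluoro, methyl or an amine at this place would also act in opposite directions on the two cores. They also leave open which feature outside this ring sets the direction.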